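The compounds below may be only part of what the source reports. "The series", "measured", "known", "first", "only" and "open" are said of these compounds alone.

Measured so far:
compound 1 `CCOC(=O)C1=Cc2ccccc2OC1(OCc1cn(CC(=O)Nc2ccc(C)cc2)nn1)C(F)(F)F` — > 150000 nM
compound 2 `O=C(O)C1=Cc2ccccc2OC1(OCc1cc(-c2ccc([N+](=O)[O-])cc2)no1)C(F)(F)F` — 100000 nM

Both compounds share the core of compound 1. In a functional assay on DU-145 cells (Homo sapiens) for inhibition, read by MTT assay, with a stated time of 24 h (a higher number here means a weaker inhibitor, a lower number a stronger inhibitor), compound 1 returns a limit rather than a number, > 150000 nM. It sits at the limit of > 150000 nM in this assay, at which 1 of the 2 values shown sits. In this assay compound 2 gives 100000 nM, a number, though a very weak one. Compound 1 thus stands at the weak end of what has been measured, with no number of its own.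

Compound 3 `CCOC(=O)C1=Cc2ccccc2OC1(OCc1cn(CC(=O)Nc2ccccc2F)nn1)C(F)(F)F` is not yet measured. It differs from compound 1 in one place: 2-fluorophenyl in place of 4-methylphenyl on an amide-type nitrogen. The change swaps one aryl group on the amide-type nitrogen for another of equal heavy-atom count. Within the data shown here, no step between measured compounds bears on this swap. With compound 1 sitting at the limit of > 150000 nM in this assay, at which 1 of the 2 values shown sits, the step from compound 1 to compound 3 is expected to be none beyond the scatter, a number no higher from compound 1 to compound 3 (the limit leaves the size open). Compound 3 is therefore estimated at 150000 nM, between 50000 nM and 400000 nM, most likely again reported only as a limit in this assay.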

Compound 3, half-maximal inhibitory concentration: 33900 nM
Compound 3: the middle estimate sits 4.4-fold (0.65 log units) above what was measured, and the stated range ends above it.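

In this assay, the aryl group on the amide-type nitrogen affects the read-out: 2-fluorophenyl in place of 4-methylphenyl gives an at least 4.4-fold lower number from compound 1 to compound 3 (0.64 log units; beyond the scatter). With the rest of the structure unchanged, this single swap separates a compound with a measured number from one without. The value of compound 1 is a limit, not a number, so the full size of the step stays open: the limit of > 150000 nM in this assay, at which 1 of the 3 values shown sits.

The compounds shown leave open whether the step follows from the loss of 4-methylphenyl or the entry of 2-fluorophenyl, and phenyl, 2-methylphenyl or 4-fluorophenyl would help to separate the two. They also leave open whether a non-aryl group on the same nitrogen, such as a longer alkyl chain or one ending in an amine or a carboxylic acid, would keep this gain.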